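The compounds below may be only part of what the source reports. "The series", "measured", "known", "first", "only" and "open" are said of these compounds alone.

Values measured in a physicochemical assay for lipophilicity, measured as octanol-water partition; a higher number here means a more lipophilic compound, a lower number a more polar compound:

compound 1 `O=C(NNc1ccnc2cc(Cl)ccc12)c1ccccc1/N=C/c1ccc(Br)cc1`: 5.76
compound 2 `Cc1ccc(/C=N/c2ccccc2C(=O)NNc2ccnc3cc(Cl)ccc23)cc1`: 5.31
compound 3 `COc1cc(/C=N/c2ccccc2C(=O)NNc2ccnc3cc(Cl)ccc23)cc(OC)c1OC`: 4.94

Compound 1 has the highest number of these three in this assay, and both of the others lie below it by more than the scatter. Compound 4 `N#Cc1ccc(/C=N/c2ccccc2C(=O)NNc2ccnc3cc(Cl)ccc23)cc1` has not yet been measured. It keeps the core of compound 1 and changes one group, with cyano in place of bromo on an aromatic carbon, para to a large group (cyano in place of bromo on an aromatic carbon). The 4-bromophenyl thus becomes a 4-cyanophenyl.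

Among the compounds with values here, only one measured step replaces this same bromo: a number 0.45 log units lower from compound 1 to compound 2 (beyond the scatter), a modest step beyond the scatter, with methyl as the new group. Compound 3 also sits lower at 4.94, but it differs from compound 1 in more than one place and offers no single-change comparison.

A downward step is therefore expected for compound 4 as well. Within the data shown here, the cyano brings in a hydrogen-bond acceptor, and on that reading the drop is expected to exceed a number 0.45 log units lower from compound 1 to compound 2 (beyond the scatter), although no measured step tests this. The estimated step is a number 1.06 log units lower from compound 1 to compound 4 (beyond the scatter). For compound 4 the expected value is 4.7, with an estimated range from 4.2 to 5.2.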

Compound 4, partition coefficient: 4.83
For compound 4 the middle estimate is 0.13 log units below the measured one; measured number inside the range.
By their numbers in this assay, from the lowest: compounds 4 and 3 (each within the scatter of the next); then compound 2; then compound 1.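

Cyano in place of bromo gives a number 0.93 log units lower from compound 1 to compound 4 (beyond the scatter) and cyano in place of methyl gives a number 0.48 log units lower from compound 2 to compound 4 (beyond the scatter) on the same aromatic carbon, para to a large group. This single place therefore now has three groups that can be compared directly in this assay with the core held constant: bromo gives the highest number, methyl the middle one and cyano the lowest, and each gap lies beyond the scatter. Unlike bromo and methyl, cyano carries a hydrogen-bond acceptor, but no measurement here connects that feature or any other to the size of these steps or explains why the numbers fall in this order.

The compounds shown leave open where other groups would fall in this order, such as a hydroxyl or an amine, a carboxylic acid with its charge-bearing potential, or a longer chain such as butyl. They also leave open whether bromo, methyl and cyano would keep the same order at another carbon of this ring or on a different core.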